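A few compounds are considered here, and "the series" means these few. Any claim that something is new, unique, unknown or untested is made for them only; others in the source may bear on it.

In a functional assay on the whole organism (strain Wistar) with Rattus norvegicus as the target, with a stated time of 5 min (on this read-out lower numbers stand for an effect already at smaller amounts and higher numbers for an effect only at larger amounts of compound), compound 1 `CCC1(CCCCN2CCN(c3ccc(F)cc3)CC2)C(=O)Nc2ccccc21` gives 10 mg/kg. Compound 2 `O=C1Nc2ccc(F)cc2C1CCCCN1CCN(c2ccc(F)cc2)CC1` reaches only a limit of the assay in this assay, > 10 mg/kg, so no number stands for it; this limit is the limit of > 10 mg/kg in this assay, at which 1 of the 2 values shown sits. Compound 3 `CCC1(CCCCN2CCN(c3ccc(F)cc3)CC2)C(=O)Nc2ccc(F)cc21` differs from compound 2 by ethyl in place of hydrogen on a saturated ring carbon. Compound 1 carries the same ethyl on the shared core and gives a number in this assay, so a move toward smaller amounts is expected, though the limit on compound 2 leaves the size of that move open. Compound 3 is expected at 10 mg/kg, within 3 mg/kg to 30 mg/kg. This amounts to an expected step of a number no higher from compound 2 to compound 3 (the limit leaves the size open).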

Compound 3, minimum effective dose: > 20 mg/kg
Compound 3 was reported as a limit (the forecaster's own chance of this, stated with the estimate: 40%); at least 2.0-fold (0.30 log units) between middle value and limit.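

With ethyl held on the saturated ring carbon, fluoro in place of hydrogen on an aromatic carbon gives an at least 2.0-fold higher number from compound 1 to compound 3 (0.30 log units; that floor lies within the scatter), so the fluoro change is not yet shown to matter beyond the scatter. Compound 3 gives only a limit, not a number. The step between the limits of compound 2 and compound 3 cannot be read, so the effect of ethyl in the fluoro series remains unsized.

Still open, as far as these compounds go, is where compound 2 and compound 3 would give numbers at larger amounts. Also open, from the compounds shown here alone, is whether methyl or a longer chain on that ring carbon gives a number with the fluoro present.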